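Methoxy additions in one antiproliferative series

The source may hold more compounds than are shown below. What is called first, only, known or untested is meant among the compounds shown, and "the series" means these compounds.

Compound 1 `C=C(Br)C(=O)Nc1ccc(C(=O)/C=C/c2ccccc2)cc1`: 880 nM in a functional assay on L1210 cells (Mus musculus) for antiproliferative activity, with a stated time of 48 h; a higher number here means a weaker inhibitor, a lower number a stronger inhibitor
Compound 2 `C=C(Br)C(=O)Nc1ccc(C(=O)/C=C/c2cccc(OC)c2)cc1`: 1100 nM in this assay
Compound 3 `C=C(Br)C(=O)Nc1ccc(C(=O)/C=C/c2ccc(OC)cc2OC)cc1`: 520 nM in this assay

Compound 2 differs from compound 1 by methoxy in place of hydrogen on an aromatic carbon; the step is a 1.3-fold higher number from compound 1 to compound 2 (0.10 log units; within the scatter). Compound 3 and compound 1 give numbers within the scatter of each other, while compound 3 against compound 2 falls beyond it. The difference between the core of compound 1 and the core of compound 3 is not broken down here.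

Compound 4 `C=C(Br)C(=O)Nc1ccc(C(=O)/C=C/c2ccc(OC)c(OC)c2OC)cc1` is not yet measured in this assay. It differs from compound 3 by methoxy in place of hydrogen on an aromatic carbon. This is the same kind of change as from compound 1 to compound 2, but here the place is also ortho to two methoxy groups. A step of a 1.2-fold higher number from compound 3 to compound 4 (0.08 log units; within the scatter) is expected, set beside a 1.3-fold higher number from compound 1 to compound 2 (0.10 log units; within the scatter), because the step of a 1.3-fold higher number from compound 1 to compound 2 (0.10 log units; within the scatter) stayed within the scatter. Compound 4 is estimated at 620 nM in this assay, expected between 300 nM and 1300 nM.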

Compound 4, half-maximal inhibitory concentration: 630 nM
Beside the measured number, compound 4's estimate is 1.0-fold (0.01 log units) below it, and the stated range covers the measured number.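

On the core of compound 3, methoxy in place of hydrogen on an aromatic carbon gives a 1.2-fold higher number from compound 3 to compound 4 (0.08 log units; within the scatter) in this assay. On both cores the change stays within the scatter, including here, where the new methoxy is ortho to two methoxy groups: the same change on two cores in this assay, a 1.3-fold higher number (0.10 log units; within the scatter) from compound 1 to compound 2 and a 1.2-fold higher number (0.08 log units; within the scatter) from compound 3 to compound 4, 1.0-fold (0.01 log units) apart, within the scatter of two such steps. For the compounds shown here, this shows only that the change leaves no readable step on these two cores; it does not show that the two steps are truly equal, or that the same would hold on any other core or at any other place on the ring.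

Still open, on these data alone, is whether an amine, a carboxylic acid or a longer chain such as ethoxy at this place would give a step beyond the scatter. Also open, as far as these compounds go, is whether a step on these cores would appear in any other assay.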